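Amide-nitrogen substituent: from compound 2 to compound 3

The compounds below may be only part of what the source reports. "The series", "measured", "known", "first", "only" and "open" are said of these compounds alone.

In a functional assay (plasma) with Oryctolagus cuniculus as the target (on this read-out higher numbers stand for weaker inhibition and lower numbers for stronger inhibition), compound 2 (`Cc1nc2cnccc2n1CC1CCN(C(=O)NC2(c3ccccc3)CC2)CC1`) gives the lower of the two numbers at 17 nM while compound 1 (`Cc1nc2cnccc2n1CC1CCN(C(=O)N[C@@H](C)c2ccccc2)CC1`) gives 41 nM as the comparison. Compound 3 (`CCOC(=O)[C@H](CC(C)C)NC(=O)N1CCC(Cn2c(C)nc3cnccc32)CC1`) carries 1-(ethoxycarbonyl)-3-methylbutyl in place of 1-phenylcyclopropyl on an amide-type nitrogen. Going by the values given here, one measured step bears on this place, and it is modest (a 2.4-fold lower number from compound 1 to compound 2 (0.38 log units; beyond the scatter)). Among the compounds with values here, no measured compound lacks the phenyl ring, so the direction is poorly supported. In this assay no change beyond the scatter is expected, and the expected step is a 1.8-fold higher number from compound 2 to compound 3 (0.25 log units; within the scatter) with a slight lean upward. For compound 3 the estimate is 30 nM with an expected range from 8 nM to 110 nM in this read-out.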

Compound 3, half-maximal inhibitory concentration: 12 nM
Compound 3: the middle estimate sits 2.5-fold (0.40 log units) above what was measured; low and high end bracket the measured number.
By their numbers in this assay, from the lowest: compounds 3 and 2 (each within the scatter of the next); then compound 1.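

In this assay a ring-free group on the amide-type nitrogen serves here: with 1-(ethoxycarbonyl)-3-methylbutyl in place of 1-phenylcyclopropyl the step is a 1.4-fold lower number from compound 2 to compound 3 (0.15 log units; within the scatter) and so no phenyl ring is required in this pair. Against 1-phenylethyl the same group gives a 3.4-fold lower number from compound 1 to compound 3 (0.53 log units; beyond the scatter) in this read-out. No supporting data explain either step.

Which part of the new group matters stays open: the ethoxycarbonyl or the 3-methylbutyl chain. A free carboxylic acid in place of the ethyl ester, or the opposite stereocentre, also remains to be read.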